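A few compounds are considered here, and "the series" means these few. Any claim that something is new, unique, unknown or untested is made for them only; others in the source may bear on it.

Compound 1 `Cc1ccccc1Nc1nc(NCc2ccncc2)ncc1Cl` gives > 100000 nM as a limit
Compound 2 `CN1CCN(c2ccc(Nc3ncc(Cl)c(NCc4ccc(C(F)(F)F)cc4)n3)nc2)CC1` gives 7960 nM as a number

Going by the values given here, in a functional assay on Jurkat cells (Homo sapiens) for inhibition, read by CCK-8 assay, with a stated time of 48 h (a lower number here means a stronger inhibitor of growth, a higher number a weaker inhibitor of growth), compound 2 gives 7960 nM as the only true number available, so it has no measured neighbour to be ranked against. Compound 1 gives > 100000 nM in this assay and this is a limit of the assay, not a number.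

Compound 3 `COc1ccccc1CNc1nc(Nc2ccc(N3CCN(C)CC3)cn2)ncc1Cl` keeps the rest of compound 2 and alters one group, a 4-(trifluoromethyl)benzyl becoming a 2-methoxybenzyl: 2-methoxyphenyl in place of 4-(trifluoromethyl)phenyl on a saturated chain carbon bound to a nitrogen on an aromatic ring is the whole change. Among the compounds with values here, no measured pair shows what this swap does, so the expectation rests on compound 2 at 7960 nM alone and favours no direction. The expected change in this assay is small, within the usual scatter (a 1.1-fold lower number from compound 2 to compound 3 (0.06 log units; within the scatter)). The estimate for compound 3 is 7000 nM as the expected middle (expected range 2000 nM to 30000 nM).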

Compound 3, concentration for 50% growth inhibition: 10800 nM
For compound 3 the middle estimate is 1.5-fold (0.19 log units) below the measured one; low and high end bracket the measured number.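

In this assay, exchanging the 4-(trifluoromethyl)benzyl for a 2-methoxybenzyl gives a 1.4-fold higher number from compound 2 to compound 3 (0.13 log units; within the scatter), so compound 2 and compound 3 cannot be told apart here. Going by these compounds alone, this pair is the first reading of this position: the phenyl on the saturated chain carbon can carry either group, with its three fluorines replaced by one oxygen and one hydrogen-bond acceptor added, and the number stays within the scatter. Compound 1 differs from compound 2 in more than one place and carries a limit rather than a number, so it does not inform this step: the limit of > 100000 nM in this assay, at which 1 of the 3 values shown sits.

The pair changes both the group and where it sits on the phenyl, so it cannot show whether either matters alone. Going by these compounds, how a carboxylic acid or a cyclohexyl ring in place of the substituted phenyl would read also remains open.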